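This account rests on a few compounds, and the source may have more. Where it says the series, first, only, none or still open, it means among the compounds named here.

Compound 1 `CC1=CC[C@H](C(C)(C)NC(=S)N/N=C/c2ccccc2)CC1` is one of three analogues sharing a thiosemicarbazone core and differing only in the substitution of the benzylidene ring. In a functional assay on NCI-H460 cells (Homo sapiens) for inhibition, read by sulforhodamine B assay, with a stated time of 48 h (a lower number here means a stronger inhibitor of growth, a higher number a weaker inhibitor of growth), compound 1 gives 13000 nM, the lowest of the two numbers available. Compound 2 `COc1ccc(/C=N/NC(=S)NC(C)(C)[C@H]2CC=C(C)CC2)cc1`, which carries a methoxy group on that ring, gives 22500 nM in this assay, a step of a 1.7-fold higher number from compound 1 to compound 2 (0.24 log units; within the scatter) that stays within the scatter. Compound 3 `CC1=CC[C@H](C(C)(C)NC(=S)N/N=C/c2ccc(F)cc2)CC1`, bearing a fluoro group, gives only a limit of > 100000 nM in this assay. Measured against this limit (the limit of > 100000 nM in this assay, at which 1 of the 3 values shown sits), the step from compound 1 is an at least 7.6-fold higher number from compound 1 to compound 3 (0.88 log units; beyond the scatter), and from compound 2 it is an at least 4.4-fold higher number from compound 2 to compound 3 (0.64 log units; beyond the scatter).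

Compound 4 `CC1=CC[C@H](C(C)(C)NC(=S)N/N=C/c2ccccc2[N+](=O)[O-])CC1` has not yet been tested. It differs from compound 1 by nitro in place of hydrogen on an aromatic carbon. Both measured substitutions on the aromatic ring bear on this change: one left the number unchanged within the scatter, the other weakened growth inhibition at least modestly. Neither involves a nitro group, and the position differs, so the comparison is loose. On this basis compound 4 is expected to give 40000 nM in this assay, within a range of 10000 nM to 150000 nM, a step of a 3.1-fold higher number from compound 1 to compound 4 (0.49 log units; beyond the scatter) expected to weaken growth inhibition, with a real chance that only a limit is reported.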

Compound 4, concentration for 50% growth inhibition: 5000 nM
For compound 4 the middle estimate is 8.0-fold (0.90 log units) above the measured one; measured number below the stated range.
By their numbers in this assay, from the lowest: compound 4; then compounds 1 and 2 (each within the scatter of the next). At a limit, above all of these: compound 3.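

Within the data shown here, the nitro group, ortho to a large group, gives the first change on this aromatic ring that moves toward stronger growth inhibition in this assay, with a step of a 2.6-fold lower number from compound 1 to compound 4 (0.41 log units; beyond the scatter) that is modest but beyond the scatter. The earlier changes did not show this: methoxy gave a 1.7-fold higher number from compound 1 to compound 2 (0.24 log units; within the scatter) and fluoro, whose step rests on a limit, gave an at least 7.6-fold higher number from compound 1 to compound 3 (0.88 log units; beyond the scatter) in the opposite direction, so substitution on this ring does not in itself cost growth inhibition, and the outcome depends on the change made. Nothing given here explains why the nitro change moves the number in this direction.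

The compounds shown leave open whether the lower number belongs to the nitro group itself or to its place, ortho to a large group, as the fluoro and methoxy changes lie elsewhere on the ring. They also leave open whether an amine, a nitrile or a carboxylic acid at that same place would follow the nitro group or go the way of the fluoro compound, and whether a second substituent on the ring would add to the step seen here.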